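A few compounds are considered here, and "the series" means these few. Any claim that something is new, unique, unknown or untested is made for them only; others in the source may bear on it.

Compound 2, with the structure `CNc1nc(/C=C/c2cc(OC)c(OC)c(OC)c2)nc2ccsc12`, is the starting point of this account. In a functional assay on L02 cells (Homo sapiens) for inhibition, read by Griess assay, with stated times of 1 h and 24 h (on this read-out higher numbers stand for weaker inhibition and lower numbers for stronger inhibition), compound 2 gives only a limit of the assay, > 1000000 nM, and no number. Going by the values given here, the one other value shown, for compound 1 with the structure `COc1cc(/C=C/c2nccc(NC(C)C)n2)cc(OC)c1OC`, is also a limit of this assay: compound 1 gives < 40000 nM. Compound 3, with the structure `COc1cc(/C=C/c2nc(Nc3ccc(C(C)C)cc3)c3sccc3n2)cc(OC)c1OC`, carries 4-isopropylphenyl in place of methyl on a nitrogen on an aromatic ring. No measured step links any two of these compounds, so the size and direction of the change are uncertain; the step from compound 2 to compound 3 is expected to be an at least 5.0-fold lower number from compound 2 to compound 3 (0.69 log units; beyond the scatter), toward stronger inhibition. Compound 3 is therefore estimated at 200000 nM, within a range from 20000 nM to 2000000 nM.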

Compound 3, half-maximal inhibitory concentration: 370000 nM
The estimate for compound 3 lay 1.9-fold (0.27 log units) below the measured number, within the range that was stated.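

At this place, on a nitrogen on an aromatic ring, the change from methylamino to (4-isopropylphenyl)amino gives in this assay an at least 2.7-fold lower number from compound 2 to compound 3 (0.43 log units; beyond the scatter). The larger group therefore goes with stronger inhibition here, in a pair that differs in this one place. The true size of the step stays unknown because the value for compound 2 is only a limit: the limit of > 1000000 nM in this assay, at which 1 of the 3 values shown sits.

Going by these compounds, it remains open whether the phenyl ring alone would carry this change or the isopropyl group is also needed. Also open, on these data alone, is what a plain phenyl, a 4-methoxyphenyl or a longer alkyl chain on this nitrogen would give.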